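The source may hold more compounds than are shown below. What is called first, only, known or untested is meant among the compounds shown, and "the series" means these compounds.

Measured so far:
Compound 1, `Cc1cccc(-c2cnc(N)nc2-c2ccccc2)c1`. In an assay on CHO cells for displacement of a labelled ligand from adenosine receptor A1 (Homo sapiens), read by scintillation counting, with a stated time of 1 h, tested at 1 uM (on this read-out higher numbers stand for more inhibition at the one concentration tested (going by the name of the read-out) and lower numbers for less inhibition), compound 1 gives > 80%, which is a limit of the assay and not a number.
Compound 2, `Nc1ncc(-c2cccc(Cl)c2)c(-c2ccccc2)n1`. In this assay compound 2 gives > 80%, likewise a limit of the assay.

Among the measured compounds shown here, the only step between measured compounds, a step that the two limits leave unreadable from compound 1 to compound 2, cannot be sized, both values sitting at the limit of > 80% in this assay, at which 2 of the 2 values shown sit. Compound 2 therefore stands at the limit of this assay with no number behind it, and nothing in the measured pair separates it from compound 1.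

Compound 3, `OCCCNc1ncc(-c2cccc(Cl)c2)c(-c2ccccc2)n1`, differs from compound 2 by 3-hydroxypropyl in place of hydrogen on a nitrogen on an aromatic ring. For the measured compounds named here, none of the measured steps bears on a change at this nitrogen; the one step recorded concerns a ring substituent and is itself unreadable, so no direction or size can be drawn from it. With compound 2 already at the limit, the expectation for compound 3 is to remain near that limit, the estimated step that the limit leaves unreadable from compound 2 to compound 3 being small and uncertain. Compound 3 is estimated at 82%, within 55% to 100%, in this assay.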

Compound 3, a percentage reported as inhibition, at one concentration (the size of the read-out at that concentration, not a potency): > 80%
Compound 3: only a limit was reported (the forecaster's own chance of this, stated with the estimate: 55%); the middle value does not contradict the limit.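

In this assay compound 3 gives > 80%, again a limit of the assay and not a number. No step can be read from compound 2 to compound 3, as all the values sit at one limit: the limit of > 80% in this assay, at which 3 of the 3 values shown sit.

The compounds shown leave open how far compound 1, compound 2 and compound 3 actually differ in inhibition, and whether 3-hydroxypropyl in place of hydrogen changes it at all.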